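Benzyl to 2,3-difluorophenyl on the imidazole side chain

The compounds below may be only part of what the source reports. "The series", "measured", "known", "first", "only" and "open" are said of these compounds alone.

Among the measured compounds shown here, compound 3 `O=C(O)c1ccccc1-c1ccc(CCc2ncc(CCc3ccccc3)[nH]2)cc1` gives 1320 nM in an in vitro functional assay on cells for agonist activity at Bombesin receptor subtype-3 (Homo sapiens), read by luminescence and calcium flux (a lower number here means that less compound is needed, a higher number that more compound is needed for the effect), the second highest of the three numbers measured so far: compound 1 `O=C(O)c1ccccc1-c1ccc(CCc2ncc(CC3CCOCC3)[nH]2)cc1` gives 338 nM and sits a 3.9-fold higher number from compound 1 to compound 3 (0.59 log units; beyond the scatter), while compound 2 `O=C(O)c1ccccc1-c1ccc(CCc2ncc(Cc3ccc(Cl)cc3)[nH]2)cc1` gives 2290 nM, a difference of a 1.7-fold lower number from compound 2 to compound 3 (0.24 log units; within the scatter). Compound 4 `O=C(O)c1ccccc1-c1ccc(CCc2ncc(Cc3cccc(F)c3F)[nH]2)cc1` carries 2,3-difluorophenyl in place of benzyl on a saturated chain carbon bound to an aromatic carbon. The step that bears on this is a 1.7-fold lower number from compound 2 to compound 3 (0.24 log units; within the scatter), where a halogen on the same aromatic ring of carbon only left the number within the usual scatter; the larger shifts in the series, a 6.8-fold higher number from compound 1 to compound 2 (0.83 log units; beyond the scatter) and a 3.9-fold higher number from compound 1 to compound 3 (0.59 log units; beyond the scatter), concern the oxan-4-yl group and not a change on the ring. A step of a 1.0-fold lower number from compound 3 to compound 4 (0.01 log units; within the scatter) is therefore expected, within the scatter. Compound 4 is estimated at 1300 nM, with a range of 550 nM to 3200 nM.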

Compound 4, half-maximal effective concentration: 87 nM
For compound 4 the middle estimate is 15-fold (1.17 log units) above the measured one; the measured number lies below the stated range.
By their numbers in this assay, from the lowest: compound 4; then compound 1; then compounds 3 and 2 (each within the scatter of the next).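

At this saturated chain carbon, the substitution on the aromatic ring can move the number far beyond the scatter: in this assay there is a 15-fold lower number from compound 3 to compound 4 (1.18 log units; beyond the scatter) and, against 4-chlorophenyl, a 26-fold lower number from compound 2 to compound 4 (1.42 log units; beyond the scatter). An aromatic ring of carbon only can also outdo oxan-4-yl here, with a 3.9-fold lower number from compound 1 to compound 4 (0.59 log units; beyond the scatter) and thus a reversal of the earlier order. No data at hand explain the gain.

Open, from the compounds shown here alone, is whether a single fluorine on the ring is enough. Also open, going by these compounds, is how a methoxy group or an amine would read in place of the fluorines.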